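Dropping the hydroxy: what compound 4 should show

A few compounds are considered here, and "the series" means these few. Any claim that something is new, unique, unknown or untested is made for them only; others in the source may bear on it.

Going by the values given here, compound 2 `COc1ccc(C(=O)Nc2ccc(Cl)cc2F)c(O)c1` is the only member of this small set with an actual number in an ADME assay on RAW264.7 cells (Mus musculus) for cytotoxicity, read by MTT assay, with a stated time of 24 h (on this read-out higher numbers stand for lower toxicity in this test and lower numbers for higher toxicity in this test), where compound 2 gives 32300 nM. Compound 1 `O=C(Nc1ccc(Cl)cc1F)c1ccccc1` reaches only a limit in this assay, giving > 40000 nM. Compound 3 `COc1ccc(C(=O)Nc2ccc(Cl)cc2F)c(OCc2ccc(F)cc2F)c1` likewise sits at a limit in this assay, giving > 40000 nM. Among the compounds with values here, the one measured step, an at least 1.2-fold higher number from compound 2 to compound 3 (0.09 log units; that floor lies within the scatter), is therefore bounded by the limit of > 40000 nM in this assay, at which 2 of the 3 values shown sit, and cannot be sized further. Compound 4 `COc1ccc(C(=O)Nc2ccc(Cl)cc2F)cc1` differs from compound 2 by hydrogen in place of hydroxy on an aromatic carbon. Within the data shown here, no measured step removes this group, so the expectation rests on the narrow spread seen so far: a step in this assay of about a 1.2-fold higher number from compound 2 to compound 4 (0.09 log units; within the scatter) is expected, quite possibly ending at the same limit. Compound 4 is estimated at 40000 nM, between 18000 nM and 90000 nM.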

Compound 4, half-maximal cytotoxic concentration: > 40000 nM
Compound 4: a limit, no number (the forecaster's own chance of this, stated with the estimate: 55%); the middle value lies on the limit itself.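

Taking the hydroxy off this aromatic carbon, ortho to a large group, gives an at least 1.2-fold higher number from compound 2 to compound 4 (0.09 log units; that floor lies within the scatter) in this assay, so the free hydroxy is not required for a reading at the limit, though that floor does not separate the two compounds. The step from compound 1 to compound 4 cannot be read, as both ends are limits. The readings at this position therefore stay bounded: the limit of > 40000 nM in this assay, at which 3 of the 4 values shown sit.

The compounds shown leave open whether an amine or a carboxylic acid on this aromatic carbon would give an actual number in this assay. Going by these compounds, how far the compounds at the limit differ from one another also remains unknown.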